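Swapping the Aryl Tail: From Difluorophenyl to Chlorophenyl

The source may report more compounds than this note shows. Statements on the series, on what has been measured and on what is new or still open speak of the compounds shown alone.

Compound 1 `C#CCNC1CCc2c(SCc3cccc(C)c3)cccc21`: in an assay on isolated protein for inhibition of Amine oxidase [flavin-containing] B (Homo sapiens) (on this read-out higher numbers stand for weaker inhibition and lower numbers for stronger inhibition), compound 1 gives only the limit > 100000 nM, a bound of the assay and not a number.
Compound 2 `C#CCNC1CCc2c(SCCc3cccc(C)c3)cccc21`: in this assay compound 2 gives 0.35 nM.
Compound 3 `C#CCNC1CCc2c(SCCc3ccc(F)c(F)c3)cccc21`: in this assay compound 3 gives 3240 nM.

Compound 3 has the higher of the two numbers shown, and its nearest neighbour is compound 2, separated by the single measured step, a 9300-fold higher number from compound 2 to compound 3 (3.97 log units; beyond the scatter). Compound 4 `C#CCNC1CCc2c(SCCc3ccc(Cl)cc3)cccc21` differs from compound 3 in one place: 4-chlorophenyl in place of 3,4-difluorophenyl on a saturated chain carbon, two bonds along the chain from a sulfur. For the measured compounds named here, that one step is the only guide, and it shows that exchanging the aromatic group at this position can move the number enormously. A 4-chlorophenyl group is expected to sit between the two measured cases, so compound 4 is estimated at 30 nM in this assay, with a range from 2 nM to 500 nM, a step of a 110-fold lower number from compound 3 to compound 4 (2.03 log units; beyond the scatter) toward stronger inhibition.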

Compound 4, half-maximal inhibitory concentration: 10800 nM
Beside the measured number, compound 4's estimate is 360-fold (2.56 log units) below it; the measured number lies above the stated range.
By their numbers in this assay, from the lowest: compound 2; then compound 3; then compound 4. At a limit, above all of these: compound 1.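

Swapping 3,4-difluorophenyl for 4-chlorophenyl in this assay gives a 3.3-fold higher number from compound 3 to compound 4 (0.52 log units; beyond the scatter) and so moves the number far less than the first change of aryl group did. Measured against the 3-methylphenyl group of compound 2, the 4-chlorophenyl group gives a 31000-fold higher number from compound 2 to compound 4 (4.49 log units; beyond the scatter), so both halogen-bearing rings shown remain much weaker than compound 2. Nothing measured here explains why the 3-methylphenyl group stands so far apart.

On these data alone, whether the methyl group itself matters remains open, and a plain phenyl or a 3-chlorophenyl group could test this. A 4-methylphenyl group could show whether its ring position matters.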